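A few compounds are considered here, and "the series" means these few. Any claim that something is new, unique, unknown or untested is made for them only; others in the source may bear on it.

Measured compounds:
Compound 1, `O=C(C1CC1)N1CCN(c2nc(=O)c3cc(C(F)(F)F)cc([N+](=O)[O-])c3s2)CC1`, in an ADME assay on Vero cells (Chlorocebus sabaeus) for cytotoxicity, read by MTT assay, with a stated time of 72 h (a higher number here means that more compound is tolerated, a lower number that less compound is tolerated), gives > 125000 nM, a limit of the assay rather than a number.
Compound 2, `O=C(c1ccc(F)cc1)N1CCN(c2nc(=O)c3cc(C(F)(F)F)cc([N+](=O)[O-])c3s2)CC1`, in this assay gives > 125000 nM, again a limit rather than a number.

Within the data shown here, compound 2 thus stands at the limit in this assay, and the one other value shown is a limit as well. Among the measured compounds shown here, the single measured step, a step that the two limits leave unreadable from compound 1 to compound 2, cannot be given a size, since both of its ends sit at the limit of > 125000 nM in this assay, at which 2 of the 2 values shown sit. Compound 3, `CC(=O)N1CCN(c2nc(=O)c3cc(C(F)(F)F)cc([N+](=O)[O-])c3s2)CC1`, differs from compound 2 by methyl in place of 4-fluorophenyl on a carbonyl carbon; this is the same carbonyl carbon that carried the earlier change. No measured step bears on this change with a readable size, and all shown values rest at the limit. The expected step is a step that the limit leaves unreadable from compound 2 to compound 3, none beyond the scatter. Compound 3 is therefore estimated at 150000 nM, with a range from 60000 nM to 400000 nM, most likely reported once more as a limit.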

Compound 3, half-maximal cytotoxic concentration: > 125000 nM
Compound 3 was reported as a limit; the forecaster's own chance of this, stated with the estimate: 85%; the middle value does not contradict the limit.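

Neither new step, from compound 1 or compound 2 to compound 3, can be read, since all three compounds sit at a limit of the assay: the limit of > 125000 nM in this assay, at which 3 of the 3 values shown sit.

In this assay the compounds shown leave open at what concentration any of them reaches the half-maximal read-out, and whether the group on the carbonyl carbon matters there.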